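Removing One Trifluoromethyl From a Diaryl Growth Inhibitor

This account rests on a few compounds, and the source may have more. Where it says the series, first, only, none or still open, it means among the compounds named here.

Compound 1 `COc1cc(-c2nn(-c3cccc(NC(=O)Nc4cc(C(F)(F)F)cc(C(F)(F)F)c4)c3)cc2-c2ccncc2)ccc1Cl` and compound 2 `O=C(Nc1cccc(-n2cc(-c3ccncc3)c(-c3ccc(Cl)c(O)c3)n2)c1)Nc1ccc(Cl)c(Cl)c1` share one core and differ only at their outer ends. Within the data shown here, in a functional assay on RXF 393 cells (Homo sapiens) for inhibition, read by sulforhodamine B assay, with a stated time of 48 h (a lower number here means a stronger inhibitor of growth, a higher number a weaker inhibitor of growth), compound 1 gives 869 nM, the lower of the two numbers measured so far, and in this assay compound 2 gives 1000 nM; these two values lie within the scatter of each other, so nothing separates them. Compound 3 `COc1cc(-c2nn(-c3cccc(NC(=O)Nc4cccc(C(F)(F)F)c4)c3)cc2-c2ccncc2)ccc1Cl` follows from compound 1 by a single change: hydrogen in place of trifluoromethyl on an aromatic carbon. Among the measured compounds shown here, no measured pair shows what such a change does here, so the expectation rests on the change alone. The step from compound 1 to compound 3 is expected to be a modest loss in this assay, a 1.8-fold higher number from compound 1 to compound 3 (0.27 log units; within the scatter). Compound 3 is therefore estimated at about 1600 nM, with a likely range from 600 nM to 4500 nM.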

Compound 3, concentration for 50% growth inhibition: 777 nM
Estimate against measurement, compound 3: 2.1-fold (0.31 log units) above, and the stated range covers the measured number.
By their numbers in this assay, from the lowest: compounds 3, 1 and 2 (each within the scatter of the next).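

In this assay, among these compounds, this is the first pair of compounds that differ in one place, and it gives a 1.1-fold lower number from compound 1 to compound 3 (0.05 log units; within the scatter). The result shows that hydrogen can stand in place of one trifluoromethyl group on this aromatic carbon, with four fewer heavy atoms, and leave no difference that this measurement can separate from scatter. Compounds 1 and 2 could not show this, as they differ at their outer ends in more than one place, and nothing shown here gives a measured reason for the result.

From the compounds shown here alone, what happens when the remaining trifluoromethyl group is also replaced by hydrogen stays open. So does the effect of a different group at this place, such as an amine or a carboxylic acid, on growth inhibition in these cells.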